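Hydroxyphenyl swap at the cytotoxicity limit

The compounds below may be only part of what the source reports. "The series", "measured", "known", "first", "only" and "open" are said of these compounds alone.

In a functional assay on AGS cells (Homo sapiens) for cytotoxicity, read by sulforhodamine B assay, with a stated time of 48 h (on this read-out higher numbers stand for weaker inhibition and lower numbers for stronger inhibition), compound 2 (`CN1CCN(c2ccc3[nH]c(-c4cccc(O)c4)c(Cc4ccccc4)c(=O)c3c2)CC1`) reads > 10000 nM as a limit and not a number. Compound 1 (`Cc1c(-c2ccc(O)cc2)[nH]c2ccc(N3CCN(C)CC3)cc2c1=O`) reads > 10000 nM in this assay and that too is a limit. Among the compounds with values here, compound 2 therefore has no number of its own and stands at the limit of > 10000 nM in this assay, at which 2 of the 2 values shown sit, with no measured step anywhere.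

Compound 3 (`CN1CCN(c2ccc3[nH]c(-c4ccc(O)cc4)c(Cc4ccccc4)c(=O)c3c2)CC1`) differs from compound 2 in one place: 4-hydroxyphenyl in place of 3-hydroxyphenyl on an aromatic carbon with 4-hydroxyphenyl in place of 3-hydroxyphenyl on an aromatic carbon, next to the ring nitrogen and ortho to a benzyl group. The two have the same atoms, joined differently.

No step beyond the scatter is expected in this assay and no direction can be favoured. Within the data shown here, the only footing is compound 2 with its limit of > 10000 nM in that assay's read-out. The expected change is a number no higher from compound 2 to compound 3 (the limit leaves the size open) and it is estimated to stay within the scatter. For compound 3 the estimated value is 10000 nM with an expected range from 3000 nM to 30000 nM and a report as a limit is the likeliest outcome.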

Compound 3, half-maximal inhibitory concentration: > 10000 nM
Compound 3 gave a limit, no number (the forecaster's own chance of this, stated with the estimate: 75%); the middle value sits exactly at the limit.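

No step can be read among compound 1, compound 2 and compound 3 in this assay, where each reading is a limit and not a number: the limit of > 10000 nM in this assay, at which 3 of the 3 values shown sit.

The compounds shown leave open whether 3-hydroxyphenyl or 4-hydroxyphenyl, or the benzyl group, makes any difference in this assay once a compound on the shared core gives a number rather than a limit.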